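Replacing a Dienoyl Amide with a Tosyl Sulfonamide

The compounds below may be only part of what the source reports. "The series", "measured", "known", "first", "only" and "open" are said of these compounds alone.

Measured compounds:
compound 1, `CCCCCCCCCCCCCCNC(=O)[C@@H](N)[C@@H](C)O`, giving 18700 nM in a functional assay on SW-620 cells (Homo sapiens) for cytotoxicity, read by MTT assay, with a stated time of 48 h; on this read-out higher numbers stand for weaker inhibition and lower numbers for stronger inhibition
compound 2, `CCCCCCCCCCCCCCNC(=O)[C@@H](NC(=O)c1cc2ccccc2o1)[C@@H](C)O`, giving 26700 nM
compound 3, `C/C=C/C=C/C(=O)N[C@H](C(=O)NCCCCCCCCCCCCCC)[C@@H](C)O`, giving 200000 nM

Compound 3 gives the highest number of the three and is thus the weakest inhibitor among them: the step of an 11-fold higher number from compound 1 to compound 3 (1.03 log units; beyond the scatter) is large and a 7.5-fold higher number from compound 2 to compound 3 (0.87 log units; beyond the scatter) is modest, whereas a 1.4-fold higher number from compound 1 to compound 2 (0.15 log units; within the scatter) stays within the scatter. Compound 4, `CCCCCCCCCCCCCCNC(=O)[C@@H](NS(=O)(=O)c1ccc(C)cc1)[C@@H](C)O`, arises from compound 3 by (4-methylphenyl)sulfonyl in place of (penta-1,3-dien-1-yl)carbonyl on an amine nitrogen. For the measured compounds named here, no measured step exchanges an acyl group for a sulfonyl group, so the nearest guide is compound 2, which also carries an aromatic ring on the amine nitrogen and gives 26700 nM. For compound 4 a lower number is therefore expected, a 5.0-fold lower number from compound 3 to compound 4 (0.70 log units; beyond the scatter). The estimate for compound 4 is 40000 nM, with a range from 10000 nM to 200000 nM.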

Compound 4, half-maximal inhibitory concentration: 15200 nM
For compound 4 the middle estimate is 2.6-fold (0.42 log units) above the measured one, and the stated range covers the measured number.
By their numbers in this assay, from the lowest: compounds 4, 1 and 2 (each within the scatter of the next); then compound 3.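

On the amine nitrogen, in this assay, (4-methylphenyl)sulfonyl gives a far lower number than (penta-1,3-dien-1-yl)carbonyl (a 13-fold lower number from compound 3 to compound 4 (1.12 log units; beyond the scatter)). It stays within the scatter of both (1-benzofuran-2-yl)carbonyl (a 1.8-fold lower number from compound 2 to compound 4 (0.24 log units; within the scatter)) and plain hydrogen (a 1.2-fold lower number from compound 1 to compound 4 (0.09 log units; within the scatter)), so of the four groups at this position only the dienyl one stands apart. No measurement shown here explains this difference.

Still open, from the compounds shown here alone, is whether a methylsulfonyl group or a saturated hexanoyl group on this nitrogen would give a number nearer compound 4 or compound 3.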